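Chloro to (pyrrolidin-1-yl)methyl: expected plasma binding shift

A few compounds are considered here, and "the series" means these few. Any claim that something is new, unique, unknown or untested is made for them only; others in the source may bear on it.

In an ADME assay on a cell-free system (plasma, Homo sapiens) for protein binding, compound 2 `CNc1nccc(N2CC[C@H](NC(=O)Nc3ccc(Cl)c(C(F)(F)F)c3)C2)n1` gives 99.8%. Compound 1 `CNc1nccc(N2CC[C@H](NC(=O)Nc3ccc(CN(C)C)c(C(F)(F)F)c3)C2)n1` gives 94.3%, which leaves compound 2 with the lower unbound fraction of these two numeric values. Compound 3 `CCNc1nccc(N2CC[C@H](NC(=O)Nc3ccc(Cl)c(C(F)(F)F)c3)C2)n1` gives > 99.9%, and this reading is a limit of the assay, not a number.

The next change leads to compound 4 `CNc1nccc(N2CC[C@H](NC(=O)Nc3ccc(CN4CCCC4)c(C(F)(F)F)c3)C2)n1`, with (pyrrolidin-1-yl)methyl in place of chloro on an aromatic carbon, ortho to a trifluoromethyl group ((pyrrolidin-1-yl)methyl in place of chloro on an aromatic carbon).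

The step that bears most on this change is a 29-fold lower unbound fraction from compound 1 to compound 2 (1.45 log units; beyond the scatter), a large one, seen for chloro in place of (dimethylamino)methyl at the same place. Compound 4 runs that exchange the other way, with a different amine-bearing group entering. The step an at least 2.0-fold lower unbound fraction from compound 2 to compound 3 (0.30 log units; that floor lies within the scatter) sits elsewhere on the structure and has a floor within the scatter, so it adds little here. Going by the values given here, only one measured pair therefore guides the size, and no measured compound carries the (pyrrolidin-1-yl)methyl group.

The expected change is a 23-fold higher unbound fraction from compound 2 to compound 4 (1.35 log units; beyond the scatter), a large step towards more free compound and beyond the scatter. For compound 4 the estimate is 95.5%, with an expected range of 91% to 98.5%.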

Compound 4, plasma protein binding: 86.5%
Compound 4: middle estimate off by 3.0-fold (0.48 log units) (unbound fraction), on the low side; the measured number lies below the stated range.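

With a second amine-bearing group now read against chloro, the large shift at this position in this assay no longer rests on a single pair: a 68-fold higher unbound fraction from compound 2 to compound 4 (1.83 log units; beyond the scatter), for (pyrrolidin-1-yl)methyl in place of chloro. The identity of the amine also counts, since the two amine-bearing groups do not read alike: a 2.4-fold higher unbound fraction from compound 1 to compound 4 (0.37 log units; beyond the scatter), a modest step beyond the scatter, for pyrrolidin-1-yl in place of dimethylamino. Across these three compounds, the exchange of chloro for an amine-bearing group therefore accounts for most of the range at this position, and the exchange of one amine for the other for a smaller share.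

A (morpholin-4-yl)methyl or (piperidin-1-yl)methyl group at this position would show whether the unbound fraction keeps moving with the amine or whether the pyrrolidine result stands alone. Whether an amine-bearing group has the same effect alongside the larger ethyl group on the other side of the molecule also remains open, as compound 3 gives a limit and not a number: the limit of > 99.9% in this assay, at which 1 of the 4 values shown sits.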